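The source may hold more compounds than are shown below. What is called first, only, known or untested is meant among the compounds shown, and "the series" means these compounds.

In an ADME assay on the whole organism (Mus musculus, strain CD-1) for pharmacokinetics, at a dose of 10 mg/kg by the oral route (a lower number here means less compound in the circulation, a higher number more compound in the circulation at the dose given), three compounds have been measured so far:

compound 1 `COc1cc([C@](O)(CCN(C)C)[C@@H](c2cc3cc(C#N)ccc3nc2OC)c2cccc(C)c2F)cc(OC(F)F)n1` (8600 ng.h/mL)
compound 2 `COc1cc([C@](O)(CCN(C)C)[C@@H](c2cc3cc(C#N)ccc3nc2OC)c2ccnc(OC)c2OC)cc(OC(F)F)n1` (3000 ng.h/mL)
compound 3 `CCOc1cc([C@](O)(CCN(C)C)[C@@H](c2cc3cc(Br)ccc3nc2OC)c2ccnc(OC)c2OC)cc(OC(C)C)n1` (32000 ng.h/mL)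

Compound 1 stands second highest of these three, above compound 2 and below compound 3. Compound 4 `COc1nc2ccc(C#N)cc2cc1[C@@H](c1cccc(C)c1F)[C@@](O)(CCN(C)C)c1cc(SC)nc(SC)c1` departs from compound 1 as follows: a group of 10 heavy atoms (7 carbon, 1 nitrogen, 2 sulfur; one six-membered aromatic ring with 1 hetero atom) in place of a group of 12 heavy atoms (7 carbon, 1 nitrogen, 2 oxygen, 2 fluorine; one six-membered aromatic ring with 1 hetero atom), on a saturated chain carbon bound to an oxygen on a saturated carbon and two saturated chain carbons. Among the compounds with values here, the one measured single-place step, a 2.9-fold lower number from compound 1 to compound 2 (0.46 log units; beyond the scatter), is modest and lies at another place, on a saturated chain carbon bound to an aromatic carbon and a saturated chain carbon. Compound 3 differs from the others at several places, so its value cannot be assigned to this group. Within the data shown here, with no measured step at this place, no step beyond the scatter is expected in this assay, and no direction can be favoured. For compound 4 the estimate is 7500 ng.h/mL, with an expected range from 2500 ng.h/mL to 22000 ng.h/mL. The estimate amounts to a 1.1-fold lower number from compound 1 to compound 4 (0.06 log units; within the scatter).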

Compound 4, area under the concentration-time curve: 2400 ng.h/mL
Estimate against measurement, compound 4: 3.1-fold (0.49 log units) above; measured number outside the range, below it.
By their numbers in this assay, from the lowest: compounds 4 and 2 (each within the scatter of the next); then compound 1; then compound 3.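

In this assay, the place on a saturated chain carbon bound to an oxygen on a saturated carbon and two saturated chain carbons now has a measured step: the sulfur-bearing group of 10 heavy atoms, in place of the group of 12 heavy atoms, gives a 3.6-fold lower number from compound 1 to compound 4 (0.55 log units; beyond the scatter). This modest step shows that exposure responds to a change at this place, and not only at the place changed in compound 2. No measurement shown offers an explanation for it. On these data alone, the two groups differ in several atoms at once, so which atoms carry the step stays open. So does the effect of a ring bearing an amine or a carboxylic acid here.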